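Methyl in Place of Hydrogen on the Ring Nitrogen

The compounds below may be only part of what the source reports. "The series", "measured", "known", "first", "only" and "open" are said of these compounds alone.

Compound 1, `CNc1nc(-c2cc(OC)c(OC)c(OC)c2)c(-c2ccc(C)cc2)s1`: in a functional assay on HeLa cells (Homo sapiens) for antiproliferative activity, read by MTT assay, with a stated time of 72 h (on this read-out higher numbers stand for weaker inhibition and lower numbers for stronger inhibition), compound 1 gives 69.1 nM.
Compound 2, `CNc1nc(-c2cc(OC)c(OC)c(OC)c2)c(-c2ccc(C(F)(F)F)cc2)s1`: in this assay compound 2 gives 3400 nM.
Compound 3, `CCOc1ccc(-c2sc(NC)nc2-c2cc(OC)c(OC)c(OC)c2)cc1`: in this assay compound 3 gives 13.2 nM.

Compound 1 stands second highest of the three numbers. Its nearest neighbour is compound 3, reached by a 5.2-fold lower number from compound 1 to compound 3 (0.72 log units; beyond the scatter). Its furthest is compound 2, reached by a 49-fold higher number from compound 1 to compound 2 (1.69 log units; beyond the scatter). Between those two, a 260-fold lower number from compound 2 to compound 3 (2.41 log units; beyond the scatter), so the group on the aromatic carbon of the shared core moves the number over a wide span.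

Compound 4, `COc1cc(-c2nc(N(C)C)sc2-c2ccc(C)cc2)cc(OC)c1OC`, differs from compound 1 in one place: methyl in place of hydrogen on a nitrogen on an aromatic ring. The nitrogen on the aromatic ring carries an aromatic carbon and a saturated chain carbon as its other neighbours, and the change reads methylamino to dimethylamino. No measured step touches this nitrogen; every step shown swaps a group on an aromatic carbon, so none bears directly on the new change. For the measured compounds named here, the measured steps show only that the shared core tolerates little, so a modest step in this assay is expected, toward a higher number. Compound 4 is estimated at 150 nM, within 40 nM to 600 nM, which is expected to mean a 2.2-fold higher number from compound 1 to compound 4 (0.34 log units; beyond the scatter).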

Compound 4, half-maximal inhibitory concentration: 4140 nM
The estimate for compound 4 lay 28-fold (1.44 log units) below the measured number; measured number above the stated range.
By their numbers in this assay, from the lowest: compound 3; then compound 1; then compounds 2 and 4 (each within the scatter of the next).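

In this assay, for the compounds shown here, methyl in place of hydrogen on the nitrogen on an aromatic ring gives a 60-fold higher number from compound 1 to compound 4 (1.78 log units; beyond the scatter) and is the first measured sign that this nitrogen, and not only the group on the aromatic carbon, moves the number strongly. Alongside a 49-fold higher number from compound 1 to compound 2 (1.69 log units; beyond the scatter) at the aromatic carbon, this change of a single heavy atom, methylamino to dimethylamino, also counts as a large step, so a small change at this nitrogen is not a minor one on this read-out. Nothing available here accounts for why the step is so large.

The compounds shown leave open whether the higher number follows the loss of the hydrogen on this nitrogen or the presence of the second methyl, a question that an unsubstituted amino group, an ethylamino group or an acetylamino group in place of methylamino would help to separate. They also leave open whether the ethoxy group of compound 3 would keep its low number with dimethylamino in place of methylamino.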